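Cytotoxicity notes on the thiocarbamate series

The compounds below may be only part of what the source reports. "The series", "measured", "known", "first", "only" and "open" are said of these compounds alone.

Two members of this series carry cytotoxicity numbers. In an ADME assay on MT4 cells (Homo sapiens) for cytotoxicity, read by MTT assay (on this read-out higher numbers stand for lower toxicity in this test and lower numbers for higher toxicity in this test), compound 1 `O=C1c2ccccc2C(=O)N1CCOC(=S)N(C(=O)c1ccc(Cl)c(Cl)c1)c1ccccc1` gives 52000 nM. In this assay compound 2 `O=C1c2ccccc2C(=O)N1CCOC(=S)N(C(=O)c1cccc(F)c1F)c1ccc(Cl)cc1` gives 58000 nM. Among the measured compounds shown here, compound 2 and compound 1 lie within the scatter of each other, so the two numbers show no difference in toxicity between them, and no step between them is drawn here because the two structures differ in more than one place.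

Compound 3 `O=C1c2ccccc2C(=O)N1CCOC(=S)N(C(=O)c1cc([N+](=O)[O-])ccc1Cl)c1ccc(Cl)cc1` is not yet measured. It differs from compound 2 by 2-chloro-5-nitrophenyl in place of 2,3-difluorophenyl on a carbonyl carbon.

Both measured numbers sit in the same narrow band, and nothing among them points in either direction for this change. The step from compound 2 to compound 3 is therefore expected to be a 1.2-fold lower number from compound 2 to compound 3 (0.06 log units; within the scatter), that is, none beyond the scatter. For compound 3 the expected value is 50000 nM, with a likely range from 25000 nM to 100000 nM.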

Compound 3, half-maximal cytotoxic concentration: 45000 nM
Compound 3: the middle estimate sits 1.1-fold (0.05 log units) above what was measured; the measured number falls inside the stated range.
By their numbers in this assay, from the lowest: compounds 3, 1 and 2 (each within the scatter of the next).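

On the carbonyl carbon whose other neighbour is the amide-type nitrogen, 2-chloro-5-nitrophenyl in place of 2,3-difluorophenyl gives a 1.3-fold lower number from compound 2 to compound 3 (0.11 log units; within the scatter) in this assay, so this exchange shows no difference in toxicity in this test. As the only single-place comparison shown, it adds that this aryl group can be exchanged for one that brings hydrogen-bond acceptors and a double bond outside the ring, with no shift beyond the scatter. No measurement at hand bears on why the number holds across this exchange.

On these data alone, whether an amine or a carboxylic acid on this phenyl ring, or a longer chain in its place, would also stay within the scatter remains open. Also open, as far as these compounds go, is whether the same exchange would read alike with a different group on the amide-type nitrogen.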